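Adding a Chloro Group to a Weak Deacetylase Inhibitor

The source may report more compounds than this note shows. Statements on the series, on what has been measured and on what is new or still open speak of the compounds shown alone.

Within the data shown here, compound 2 `CCSC(=S)SCC(=O)c1ccc(C(=O)Nc2ccccc2)cc1` gives 521 nM in an assay on HEK293 cells for inhibition of protein deacetylase HDAC6 (Homo sapiens) (on this read-out higher numbers stand for weaker inhibition and lower numbers for stronger inhibition), the highest number of the two measured here; compound 1 `CCOC(=S)SCC(=O)c1ccc(NC(C)=O)cc1` gives 90 nM, the only other value. Compound 3 `CCSC(=S)SCC(=O)c1ccc(C(=O)Nc2ccc(Cl)cc2)cc1` differs from compound 2 by a single change: chloro in place of hydrogen on an aromatic carbon. Among the measured compounds shown here, no measured pair in this set shows this change, so its effect is unknown; a step no larger than the usual scatter, in either direction, is expected. Compound 3 is therefore estimated at 420 nM, within a range of 150 nM to 1200 nM, meaning an expected step of a 1.2-fold lower number from compound 2 to compound 3 (0.09 log units; within the scatter).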

Compound 3, half-maximal inhibitory concentration: 1450 nM
Estimate against measurement, compound 3: 3.5-fold (0.54 log units) below, and the stated range ends below it.
By their numbers in this assay, from the lowest: compound 1; then compound 2; then compound 3.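

Replacing phenyl with 4-chlorophenyl gives a 2.8-fold higher number from compound 2 to compound 3 (0.44 log units; beyond the scatter) in this assay, and here a higher number means weaker inhibition. This position is therefore sensitive to substitution: a single chlorine atom is enough to move the result beyond the usual scatter. Nothing available explains the direction of this step.

From the compounds shown here alone, it remains open whether fluoro, methoxy or an amine at the same place would also raise the number. It is also unknown whether any group there could give stronger inhibition than the plain phenyl of compound 2.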